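A few compounds are considered here, and "the series" means these few. Any claim that something is new, unique, unknown or untested is made for them only; others in the source may bear on it.

Compound 2 `COc1cc(-c2cnn3cc(OC)c(C(C)(C)O)nc23)ccn1` carries a 1-hydroxy-1-methylethyl group on its core. Within the data shown here, in an assay on isolated protein for inhibition of activin receptor type-2A (Homo sapiens), read by 33P incorporation, with a stated time of 20 min, in the presence of a further agent that is not named here (a higher number here means a weaker inhibitor, a lower number a stronger inhibitor), compound 2 gives 2700 nM, the lowest of the two numbers measured so far. Its closest relative, compound 1 `COc1cc(-c2cnn3cc(OC)c(C(C)C)nc23)ccn1`, carries an isopropyl group in the same position; in this assay compound 1 gives 3800 nM. Among the measured compounds shown here, the only measured step, a 1.4-fold lower number from compound 1 to compound 2 (0.15 log units; within the scatter), stays within the scatter.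

Compound 3 `COc1cc(-c2cnn3cc(OC)c(C4CCOC4)nc23)ccn1` is the next candidate. It differs from compound 2 by oxolan-3-yl in place of 1-hydroxy-1-methylethyl on an aromatic carbon. For the measured compounds named here, no measured pair shows this particular exchange, and the one measured step at this position, from compound 1 to compound 2, was small. With so little to go on, the expectation is that the change from compound 2 to compound 3 in this assay will be a 1.1-fold higher number from compound 2 to compound 3 (0.05 log units; within the scatter), a step not clearly beyond the scatter. Compound 3 is therefore estimated at 3000 nM in this assay, with a range from 1000 nM to 9000 nM.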

Compound 3, half-maximal inhibitory concentration: 1900 nM
The estimate for compound 3 lay 1.6-fold (0.20 log units) above the measured number; measured number inside the range.
By their numbers in this assay, from the lowest: compounds 3, 2 and 1 (each within the scatter of the next).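

With oxolan-3-yl in place of 1-hydroxy-1-methylethyl on the shared core, a five-membered ring takes the place of an open group, and this assay shows a 1.4-fold lower number from compound 2 to compound 3 (0.15 log units; within the scatter) with no clear loss of inhibition. The entering oxolan-3-yl has 0 hydrogen-bond donors and the leaving 1-hydroxy-1-methylethyl has 1, so a donor on this group is not needed to keep inhibition at this level in compound 3. Replacing isopropyl gives a 2.0-fold lower number from compound 1 to compound 3 (0.30 log units; within the scatter) as well, and no measurement available here explains any of these numbers.

No exchange so far gives a step beyond the scatter, so it remains unclear how much this position can influence inhibition. Going by these compounds, whether an amine, a carboxylic acid or a longer chain here would give a clearer step stays open.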